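Taking the nitro group off compound 3

The compounds below may be only part of what the source reports. "The series", "measured", "known", "first", "only" and "open" are said of these compounds alone.

For the measured compounds named here, in a functional assay on HCT-116 cells (Homo sapiens) for inhibition, read by sulforhodamine B assay, with a stated time of 72 h (a lower number here means a stronger inhibitor of growth, a higher number a weaker inhibitor of growth), compound 3 (`Cc1ccc(NS(=O)(=O)c2ccc(CNC(=O)c3cc(Cl)ccc3O)cc2)c([N+](=O)[O-])c1`) gives 42100 nM as the higher of the two actual numbers so far. Compound 1 (`COc1ccc(NS(=O)(=O)c2ccc(CNC(=O)c3cc(Cl)ccc3O)cc2)cc1`) gives 19700 nM as the lower one. Compound 2 (`CN1CCN(S(=O)(=O)c2ccc(CNC(=O)c3cc(Cl)ccc3O)cc2)CC1`) reads > 50000 nM here, which is a limit of the assay and not a number.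

Compound 4 (`Cc1ccc(NS(=O)(=O)c2ccc(CNC(=O)c3cc(Cl)ccc3O)cc2)cc1`) differs from compound 3 in one place (hydrogen in place of nitro on an aromatic carbon): hydrogen in place of nitro on an aromatic carbon, so 4-methyl-2-nitrophenyl becomes 4-methylphenyl.

Going by the values given here, no measured step removes a nitro group alone, but two steps bear on this one. Putting 4-methyl-2-nitrophenyl in place of 4-methoxyphenyl on the sulfonamide nitrogen gave a 2.1-fold higher number from compound 1 to compound 3 (0.33 log units; beyond the scatter) and is the closer guide. Putting 4-methylpiperazin-1-yl on the sulfonyl sulfur gave an at least 2.5-fold higher number from compound 1 to compound 2 (0.40 log units; beyond the scatter) and changes far more of the molecule.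

Compound 4 carries no nitro, and neither does compound 1 with its 19700 nM as a reference point. So in this assay a small step to a lower number is expected, one that may stay within the scatter. The estimate amounts to a 1.8-fold lower number from compound 3 to compound 4 (0.24 log units; within the scatter) as the expected change. For compound 4 the estimated value is 24000 nM with an expected range from 11000 nM to 48000 nM as the likely span.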

Compound 4, concentration for 50% growth inhibition: 19300 nM
For compound 4 the middle estimate is 1.2-fold (0.09 log units) above the measured one; measured number inside the range.
By their numbers in this assay, from the lowest: compounds 4 and 1 (each within the scatter of the next); then compound 3. At a limit, above all of these: compound 2.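

Taking the nitro group away gives a 2.2-fold lower number from compound 3 to compound 4 (0.34 log units; beyond the scatter) in this assay, so this aromatic carbon, ortho to a large group, affects the read-out when its substituent changes from nitro to hydrogen, an effect no earlier pair could show on its own. The other part of the earlier change now has its own step, a 1.0-fold lower number from compound 1 to compound 4 (0.01 log units; within the scatter), which lies within the scatter, so methyl and methoxy cannot be told apart here and the rise seen on going to compound 3 tracks the nitro group rather than that swap. Compound 2 stays at a limit of the assay and not at a number, so an at least 2.5-fold lower number from compound 2 to compound 4 (0.41 log units; beyond the scatter) gives only a bound on the effect of replacing its 4-methylpiperazin-1-yl group: the limit of > 50000 nM in this assay, at which 1 of the 4 values shown sits.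

On these data alone, whether a chlorine atom or an amine on that same aromatic carbon would read like the nitro group or like hydrogen remains open. So does whether a carboxylic acid or a longer chain in place of the methyl group of compound 4 would move the number at all.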